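Methylcarbamoyl to (dimethylamino)methyl on the pyridyl arm

The source may report more compounds than this note shows. Statements on the series, on what has been measured and on what is new or still open speak of the compounds shown alone.

Measured so far in an ADME assay on microsomes from liver (Homo sapiens) for metabolic stability, read by LC-MS, using NADPH, with stated times of 5 min and 30 min, tested at 1 uM; a higher number here means faster removal of the compound, a lower number slower removal:
- compound 1, `Cc1nccn1-c1cnc(NCc2c(F)ccc3c2CCO3)c2cn[nH]c(=O)c12`, gives 8 mL.min-1.g-1.
- compound 2, `CNC(=O)c1cc(-c2cnc(NCc3c(F)ccc4c3CCO4)c3cn[nH]c(=O)c23)n(C)n1`, returns only an assay limit, < 3 mL.min-1.g-1.
- compound 3, `CNC(=O)c1ccc(-c2cnc(NCc3c(F)ccc4c3CCO4)c3cn[nH]c(=O)c23)c(C)n1`, gives 23 mL.min-1.g-1.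

Compound 3 stands highest of the two numbers, with a 2.9-fold higher number from compound 1 to compound 3 (0.46 log units; beyond the scatter) and an at least 7.6-fold higher number from compound 2 to compound 3 (0.88 log units; beyond the scatter). Compound 4, `Cc1nc(CN(C)C)ccc1-c1cnc(NCc2c(F)ccc3c2CCO3)c2cn[nH]c(=O)c12`, differs from compound 3 by (dimethylamino)methyl in place of methylcarbamoyl on an aromatic carbon. Among the measured compounds shown here, no measured step swaps these two groups on a shared ring; the known steps exchange whole aryl groups on the core, so none bears directly on this change. With that, the step is expected to stay near compound 3, a 1.2-fold lower number from compound 3 to compound 4 (0.06 log units; within the scatter), in either direction within the usual scatter. Compound 4 is therefore estimated at 20 mL.min-1.g-1, with a range of 8 mL.min-1.g-1 to 50 mL.min-1.g-1.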

Compound 4, intrinsic clearance in microsomes: 13 mL.min-1.g-1
The estimate for compound 4 lay 1.5-fold (0.19 log units) above the measured number; the measured number falls inside the stated range.
By their numbers in this assay, from the lowest: compounds 1, 4 and 3 (each within the scatter of the next, the first and the last beyond it). At a limit, below all of these: compound 2.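

In this assay, among the compounds shown here, the first change confined to this place, next to the ring nitrogen, gives a 1.8-fold lower number from compound 3 to compound 4 (0.25 log units; within the scatter), so methylcarbamoyl and (dimethylamino)methyl are not separated here. The whole-arm exchange gives a 1.6-fold higher number from compound 1 to compound 4 (0.21 log units; within the scatter), so compound 4 is also not separated from compound 1, whereas compound 3 is. The remaining step, an at least 4.3-fold higher number from compound 2 to compound 4 (0.63 log units; beyond the scatter), rests on a limit of the assay rather than a number: the limit of < 3 mL.min-1.g-1 in this assay, at which 1 of the 4 values shown sits.

Going by these compounds, whether a carboxylic acid or a morpholine at this place would also stay within the scatter remains open. So does the number for (dimethylamino)methyl on the pyrazole arm of compound 2.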